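Compound 3 to compound 4: replacing the aryl group

The source may hold more compounds than are shown below. What is called first, only, known or untested is meant among the compounds shown, and "the series" means these compounds.

Values so far in a functional assay on NCI60 cells (Homo sapiens) for antiproliferative activity, read by sulforhodamine B assay, with a stated time of 48 h (on this read-out higher numbers stand for weaker inhibition of growth and lower numbers for stronger inhibition of growth), are these
- compound 1 `COc1ccc(-c2nsc3c2NC(=O)CC3c2ccc3c(c2)OCCO3)cc1` gives 933 nM
- compound 2 `COc1ccc(-c2nsc3c2NC(=O)CC3c2cccc(Cl)c2)cc1` gives 1740 nM
- compound 3 `COc1ccc(-c2nsc3c2NC(=O)CC3c2cccc(F)c2)cc1` gives 4900 nM

Among these three, compound 3 at 4900 nM has the highest number and compound 1 at 933 nM has the lowest. Next in the series is compound 4 `COc1ccc(-c2nsc3c2NC(=O)CC3c2ccsc2)cc1` with the structural change thiophen-3-yl in place of 3-fluorophenyl on a saturated ring carbon in which thiophen-3-yl takes the place of 3-fluorophenyl on a saturated ring carbon.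

For the measured compounds named here, one measured step bears on this carbon's substituent. It is a 2.8-fold higher number from compound 2 to compound 3 (0.45 log units; beyond the scatter) for fluoro in place of chloro on an aromatic carbon, so a change on the aromatic ring alone moved the number beyond the scatter. Going by the values given here, no measured compound replaces the six-membered aromatic ring itself, so the data give no direct precedent and the uncertainty is wide.

Since compound 3 at 4900 nM already holds the highest number of the three, a modest move toward a lower number is expected rather than a large one. The expected change in this assay is a 1.8-fold lower number from compound 3 to compound 4 (0.24 log units; within the scatter) and this remains a tentative call. The estimate for compound 4 is 2800 nM with an expected range from 1000 nM to 7500 nM in this read-out.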

Compound 4, concentration for 50% growth inhibition: 302 nM
Compound 4: the middle estimate sits 9.3-fold (0.97 log units) above what was measured, outside the stated range (below it).
By their numbers in this assay, from the lowest: compound 4; then compounds 1 and 2 (each within the scatter of the next); then compound 3.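

In this assay, the substituent on this saturated ring carbon need not be a six-membered aromatic ring of carbon only: thiophen-3-yl is accepted there, with a 16-fold lower number from compound 3 to compound 4 (1.21 log units; beyond the scatter) and a 5.8-fold lower number from compound 2 to compound 4 (0.76 log units; beyond the scatter). Until now, the only step at this substituent was the halogen exchange on the phenyl ring, with a 2.8-fold higher number from compound 2 to compound 3 (0.45 log units; beyond the scatter), so the series had shown sensitivity to a ring substituent but not to the identity of the ring itself. Compound 4 adds that second kind of sensitivity, as both of its steps lie beyond the scatter, but no measurement at hand accounts for the result.

Thiophen-3-yl differs from the halophenyl groups in both ring size and the presence of sulfur, so compound 4 alone cannot separate these two changes, and furan-3-yl, thiophen-2-yl or pyridin-3-yl on the same carbon would be needed to do so. Also open, on these data alone, is whether this carbon needs an aromatic ring at all, a question that cyclopentyl, cyclohexyl or a short alkyl chain carrying an amine would address.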